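Benzylsulfanyl halogen swap and arterial inhibition in rats

A few compounds are considered here, and "the series" means these few. Any claim that something is new, unique, unknown or untested is made for them only; others in the source may bear on it.

Three compounds have been measured in a functional assay on the whole organism (artery, strain albino) with Rattus norvegicus as the target, with a stated time of 720 min, at a dose of 10 mg/kg by the oral route; a higher number here means more inhibition at the dose given (going by the name of the read-out), a lower number less inhibition:
Compound 1 `COc1ccc(C2N=C(SCc3ccccc3)NC(C)=C2C(=O)Nc2ccc(F)cc2)cc1OC` gives 1.5%.
Compound 2 `COc1ccc(C2N=C(SCc3cccc(Cl)c3)NC(C)=C2C(=O)Nc2ccc(F)cc2)cc1OC` gives 15.5%.
Compound 3 `COc1ccc(C2N=C(SCc3ccc(Cl)cc3)NC(C)=C2C(=O)Nc2ccc(F)cc2)cc1OC` gives 22.2%.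

Compound 3 holds the highest of the three numbers, though its margin over compound 2, a number 6.7 percentage points higher from compound 2 to compound 3 (within the scatter), lies within the scatter; only against compound 1 does it stand clearly apart, a number 20.7 percentage points higher from compound 1 to compound 3 (beyond the scatter). Compound 4 `COc1ccc(C2N=C(SCc3ccc(F)cc3)NC(C)=C2C(=O)Nc2ccc(F)cc2)cc1OC` differs from compound 3 by fluoro in place of chloro on an aromatic carbon. Among the compounds with values here, no measured step exchanges one halogen for another; the steps that bear on it are a number 20.7 percentage points higher from compound 1 to compound 3 (beyond the scatter) and a number 14 percentage points higher from compound 1 to compound 2 (beyond the scatter), each going from hydrogen to chloro. Compound 4 is expected to settle between the numbers of compound 1 and compound 3. The step expected is a number 10.2 percentage points lower from compound 3 to compound 4 (beyond the scatter), near the edge of the scatter. Compound 4 is estimated at 12%, within 2% to 24%.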

Compound 4, a percentage reported as inhibition, in the whole organism at one dose (the size of the read-out at that dose, not a potency): 17%
The estimate for compound 4 lay 5 percentage points below the measured number; the range from low to high includes it.
By their numbers in this assay, from the lowest: compound 1; then compounds 2, 4 and 3 (each within the scatter of the next).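

Exchanging 4-chlorobenzyl for 4-fluorobenzyl gives a number 5.2 percentage points lower from compound 3 to compound 4 (within the scatter) and so does not separate the two halogens at this position. Fluoro in place of hydrogen also counts here, with a number 15.5 percentage points higher from compound 1 to compound 4 (beyond the scatter) showing that the gain over the unsubstituted benzyl is not confined to chloro. The move from 3-chlorophenyl to 4-fluorophenyl, a number 1.5 percentage points higher from compound 2 to compound 4 (within the scatter) as printed, separates neither group from the other. Whether bromo, methoxy or an amine at the same place would hold this level remains open, and nothing available here explains why a halogen on this ring raises the number.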